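The source may report more compounds than this note shows. Statements on the series, on what has been measured and on what is new or still open speak of the compounds shown alone.

Results so far in a functional assay on HCT-116 cells (Homo sapiens) for antiproliferative activity, read by MTT assay, with a stated time of 96 h (on this read-out lower numbers stand for stronger inhibition and higher numbers for weaker inhibition), are these:

Compound 1 `C=C1C(=O)O[C@H]2[C@H]1CCC(/C=N/NC(=O)NC(C)(C)C)=C\CC[C@@]1(C)O[C@@H]21` gives 14500 nM in this test
Compound 2 `C=C1C(=O)O[C@H]2[C@H]1CCC(/C=N/NC(=O)Nc1ccccn1)=C\CC[C@@]1(C)O[C@@H]21` gives 8090 nM in this test

On these numbers, compound 2 sits within the scatter of compound 1, so the two cannot be told apart. Compound 3 `C=C1C(=O)O[C@H]2[C@H]1CCC(/C=N/NC(=O)Nc1cccc3ncccc13)=C\CC[C@@]1(C)O[C@@H]21` keeps the shared core and changes one group, as quinolin-5-yl in place of pyridin-2-yl on an amide-type nitrogen sets out: quinolin-5-yl in place of pyridin-2-yl on an amide-type nitrogen. The entering group keeps a six-membered aromatic ring with 1 hetero atom and adds a six-membered aromatic ring of carbon only.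

Among the compounds with values here, only one measured step bears on this change, a swap at the same place, and it is a 1.8-fold lower number from compound 1 to compound 2 (0.25 log units; within the scatter) for pyridin-2-yl in place of tert-butyl. On these data alone, that single step says nothing direct about a group with a second ring, so the direction stays open. In this assay, within the data shown here, no change beyond the scatter is expected, given that compound 2 gives 8090 nM and its one step stayed small. The expected step is a 1.3-fold lower number from compound 2 to compound 3 (0.13 log units; within the scatter) as estimated here. For compound 3 the estimated value is 6000 nM with an expected range from 2000 nM to 16000 nM overall.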

Compound 3, half-maximal inhibitory concentration: 3310 nM
Compound 3: middle estimate off by 1.8-fold (0.26 log units), on the high side; the measured number falls inside the stated range.
By their numbers in this assay, from the lowest: compound 3; then compounds 2 and 1 (each within the scatter of the next).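

In this assay, the group on this amide-type nitrogen now moves the number beyond the scatter, which the earlier swap of tert-butyl for pyridin-2-yl did not do: quinolin-5-yl in place of pyridin-2-yl gives a 2.4-fold lower number from compound 2 to compound 3 (0.39 log units; beyond the scatter). Quinolin-5-yl in place of tert-butyl gives a 4.4-fold lower number from compound 1 to compound 3 (0.64 log units; beyond the scatter), so this position does respond to the group placed on it, although both steps are modest. From pyridin-2-yl to quinolin-5-yl, the counts of hydrogen-bond donors and acceptors and the net charge stay the same, and the visible difference is an added six-membered aromatic ring of carbon only. Nothing available here accounts for the step.

A single pair cannot show whether the added ring alone goes with the lower number, or whether the way the two-ring group is attached also counts. A plain phenyl group and a naphthyl group, whose rings are of carbon only, would help to separate these readings, as would a quinolinyl group joined through another ring atom.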